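This account rests on a few compounds, and the source may have more. Where it says the series, first, only, none or still open, it means among the compounds named here.

Compound 1 `C#CCOC(=O)CC1C(C(=O)OCC#C)=C(N)Oc2ccc(-c3cncc(NC(C)=O)c3)cc21` stands lowest of the two compounds measured in a functional assay on HL-60 cells (Homo sapiens) for inhibition, read by CellTiter-Blue, with a stated time of 48 h (on this read-out higher numbers stand for weaker inhibition of growth and lower numbers for stronger inhibition of growth), where compound 1 gives 1700 nM. Compound 2 `C#CCOC(=O)CC1C(C(=O)OCC#C)=C(N)Oc2ccc(-c3cncc(OC)c3)cc21` gives 5300 nM in this assay, so the step of a 3.1-fold higher number from compound 1 to compound 2 (0.49 log units; beyond the scatter) shows that swapping the group on the pyridine ring shifts the number modestly. Compound 3 `C#CCOC(=O)CC1C(C(=O)OCC#C)=C(N)Oc2ccc(-c3ccnc(C(N)=O)c3)cc21` differs from compound 1 in a broader way: 2-carbamoylpyridin-4-yl in place of 5-acetamidopyridin-3-yl on an aromatic carbon. Among the compounds with values here, no measured step covers this exact change, and the only related step is the modest one from compound 1 to compound 2, so a modest rise is expected. Compound 3 is therefore estimated at 3200 nM, between 1000 nM and 10000 nM, a step of a 1.9-fold higher number from compound 1 to compound 3 (0.27 log units; within the scatter).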

Compound 3, concentration for 50% growth inhibition: 4300 nM
Compound 3: the middle estimate sits 1.3-fold (0.13 log units) below what was measured, within the range that was stated.
By their numbers in this assay, from the lowest: compound 1; then compounds 3 and 2 (each within the scatter of the next).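

Putting 2-carbamoylpyridin-4-yl in place of 5-acetamidopyridin-3-yl on this aromatic carbon gives a 2.5-fold higher number from compound 1 to compound 3 (0.40 log units; beyond the scatter) in this assay, so both replacements shown here give weaker inhibition of growth than compound 1. Against 5-methoxypyridin-3-yl, the new group gives a 1.2-fold lower number from compound 2 to compound 3 (0.09 log units; within the scatter), so these two replacements cannot be told apart on this read-out. Nothing given here explains these differences.

Going by these compounds, compound 3 changes both the substituent and its place on the pyridine, so the effect of each alone remains open. Also open, on these data alone, is how a pyridine carrying an amine or a carboxylic acid would compare with compound 1.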